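The source may hold more compounds than are shown below. What is called first, only, known or untested is meant among the compounds shown, and "the series" means these compounds.

In a functional assay on LOX IMVI cells (Homo sapiens) for cytotoxicity, read by MTT assay, with a stated time of 24 h (on this read-out lower numbers stand for stronger inhibition and higher numbers for weaker inhibition), compound 1 `COc1cc(-c2nc(-c3ccccc3)[nH]c2-c2ccnc(NCCCNS(=O)(=O)c3ccccc3)n2)ccc1F` gives 4520 nM, and compound 2 `O=S(=O)(NCCCNc1nccc(-c2[nH]c(-c3ccccc3)nc2-c2ccc(F)c(O)c2)n1)c1ccccc1` gives 9580 nM. For the measured compounds named here, compound 2 therefore holds the higher of only two numbers, which means the weaker inhibition of this pair. The two compounds differ in one place, where hydrogen stands in place of methyl on an oxygen on an aromatic ring. That change gives a 2.1-fold higher number from compound 1 to compound 2 (0.33 log units; beyond the scatter), a modest step just beyond the scatter.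

Compound 3 `O=S(=O)(NCCCNc1nccc(-c2[nH]c(-c3ccccc3)nc2-c2ccc(F)c(O)c2)n1)c1ccc(Br)cc1` keeps all of compound 2 except that phenylsulfonyl becomes (4-bromophenyl)sulfonyl: bromo in place of hydrogen on an aromatic carbon. This is bromo in place of hydrogen on an aromatic carbon, para to a large group. Going by the values given here, the one measured step, a 2.1-fold higher number from compound 1 to compound 2 (0.33 log units; beyond the scatter), lies at a different place and involves a different group, so it offers only a rough sense of how far one small change can move the number here. Among the compounds with values here, no measured compound carries bromo, so the data favour no direction.

The expected change is therefore small, with a 1.2-fold lower number from compound 2 to compound 3 (0.08 log units; within the scatter) as the estimated step. For compound 3 the estimated value is 8000 nM, with an expected range from 3500 nM to 18000 nM.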

Compound 3, half-maximal inhibitory concentration: 5660 nM
For compound 3 the middle estimate is 1.4-fold (0.15 log units) above the measured one; the range from low to high includes it.
By their numbers in this assay, from the lowest: compounds 1, 3 and 2 (each within the scatter of the next, the first and the last beyond it).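

Moving to the sulfonyl end of the molecule, the swap from phenyl to 4-bromophenyl gives a 1.7-fold lower number from compound 2 to compound 3 (0.23 log units; within the scatter) in this assay, so this change cannot be told apart from the ordinary spread of repeated measurements. For the compounds shown here, the earlier step concerned a group on an oxygen elsewhere in the molecule, whereas this one gives a first reading at this end: here, a single bromine atom on an aromatic carbon, para to a large group, produces no change that can be called real in this cell assay. No supporting measurement is available to explain this result.

One bromo group at one place is a single reading and does not show that this end of the molecule is insensitive to change in general, since a carboxylic acid, an amine or a nitrile at the same place could still move the number beyond the scatter. From the compounds shown here alone, it also remains open whether bromo would behave the same way on the methoxy-bearing partner, compound 1, or at another carbon of the same ring.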